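Notes on trimming the piperazine tail from compound 2

A few compounds are considered here, and "the series" means these few. Any claim that something is new, unique, unknown or untested is made for them only; others in the source may bear on it.

Measured compounds
compound 1, `CN(C)CCCOC(=O)Nc1cccc(Cn2nc(-n3ccc4ccc(F)cc43)ccc2=O)c1`: in a functional assay on EBC-1 cells (Homo sapiens) for inhibition, read by sulforhodamine B assay, with a stated time of 72 h (a higher number here means a weaker inhibitor, a lower number a stronger inhibitor), compound 1 gives a limit of the assay, <= 1000 nM.
compound 2, `CN1CCN(CCCOc2cnc(-c3cccc(Cn4nc(-n5ccc6ccc(F)cc65)ccc4=O)c3)nc2)CC1`: in this assay compound 2 gives 198 nM.

Going by the values given here, compound 2 carries the only actual number in the set. The other entry, that of compound 1, is a limit and not a number (the limit of <= 1000 nM in this assay, at which 1 of the 2 values shown sits). Among the compounds with values here, with a single number there is no measured step to lean on, and the pair of compound 1 and compound 2 shows only that compound 2 sits at its value while compound 1 sits at its limit.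

Compound 3, `COc1cnc(-c2cccc(Cn3nc(-n4ccc5ccc(F)cc54)ccc3=O)c2)nc1`, is not yet measured. It differs from compound 2 in one place: hydrogen in place of 2-(4-methylpiperazin-1-yl)ethyl on a saturated chain carbon bound to an oxygen on an aromatic ring. Cut one bond further out, the same change reads 3-(4-methylpiperazin-1-yl)propoxy to methoxy.

Within the data shown here, no measured step informs the change directly. Removing the piperazine-bearing chain is expected to cost some potency in this assay, with the step from compound 2 to compound 3 estimated at a 2.3-fold higher number from compound 2 to compound 3 (0.36 log units; beyond the scatter), beyond the usual scatter but not far beyond it. Compound 3 is accordingly estimated at 450 nM, within a range of 130 nM to 1600 nM.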

Compound 3, half-maximal inhibitory concentration: > 1000 nM
Compound 3 gave a limit, no number; the forecaster's own chance of this, stated with the estimate: 12%; middle value at least 2.2-fold (0.34 log units) away from the limit.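

Going by these compounds alone, this is the first readable step. At the saturated chain carbon bound to an oxygen on an aromatic ring, hydrogen in place of 2-(4-methylpiperazin-1-yl)ethyl, which also reads as 3-(4-methylpiperazin-1-yl)propoxy to methoxy, gives a loss of potency in this assay. The 3-(4-methylpiperazin-1-yl)propoxy tail therefore counts for the potency of compound 2 in this assay, and methoxy does not hold that potency on the same scaffold. Only the lower end of the loss is fixed, with an at least 5.0-fold higher number from compound 2 to compound 3 (0.70 log units; beyond the scatter), because compound 3 sits at a limit of the assay and not at a number: the limit of > 1000 nM in this assay, at which 1 of the 3 values shown sits.

The other step gives only a number no lower from compound 1 to compound 3 (the limit leaves the size open), so the two tails on the shared core cannot be ranked against each other. Open too, on these data alone, is whether the loss follows the terminal amine or the chain itself, a question that a plain propoxy chain with no amine, or a morpholine in place of the 4-methylpiperazine on the same propoxy chain, would bear on directly.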